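Five- or Six-Membered Ring on the Thiocarbonyl Carbon

The source may hold more compounds than are shown below. What is called first, only, known or untested is meant among the compounds shown, and "the series" means these compounds.

Compound 1 `Cc1cccc(/C(N)=N/NC(=S)N2CCCCC2)n1` gives 65.2% in a functional assay on A-431 cells (Homo sapiens) for cytotoxicity, read by MTT assay, with a stated time of 72 h, tested at 30 uM; a lower number here means less inhibition of growth, a higher number more inhibition of growth at the concentration tested.
Compound 2 `Cc1cccc(/C(N)=N/NC(=S)N2CCCC2)n1` gives 72.2% in this assay.
Compound 3 `Cc1ccnc(/C(N)=N/NC(=S)N2CCCCC2)c1` gives 62.8% in this assay.

Compound 1 and compound 3 are built from the same atoms joined differently; the difference between the two cores is not broken down here. Their values in this assay lie within the usual scatter of each other, as does the value of compound 2, so no order among the three is claimed.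

Compound 2 differs from compound 1 by pyrrolidin-1-yl in place of piperidin-1-yl on a thiocarbonyl carbon. This change brought a number 7 percentage points higher from compound 1 to compound 2 (within the scatter).

Compound 4 `Cc1ccnc(/C(N)=N/NC(=S)N2CCCC2)c1` has not yet been measured. It differs from compound 3 by pyrrolidin-1-yl in place of piperidin-1-yl on a thiocarbonyl carbon, the same change made at the same place as in the pair of compound 1 and compound 2.

Because a number 7 percentage points higher from compound 1 to compound 2 (within the scatter) was small, the step from compound 3 to compound 4 is expected to be of similar size, a number 6.2 percentage points higher from compound 3 to compound 4 (within the scatter), which is an estimate resting on that one earlier pair alone. Compound 4 is therefore expected to reach about 69% in this assay, with a likely range estimated from 56% to 82%.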

Compound 4, percent growth inhibition at one concentration: 84.2%
For compound 4 the middle estimate is 15.2 percentage points below the measured one; measured number above the stated range.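

In this assay, pyrrolidin-1-yl in place of piperidin-1-yl on a thiocarbonyl carbon brought a number 21.4 percentage points higher from compound 3 to compound 4 (beyond the scatter), so on this core the change gives a step that stands clear of the usual variation. Set beside the earlier pair, the change did not carry over at a fixed size from one core to the other: the same change on two cores in this assay, a number 7 percentage points higher (within the scatter) from compound 1 to compound 2 and a number 21.4 percentage points higher (beyond the scatter) from compound 3 to compound 4, 14.4 percentage points apart, beyond the scatter of two such steps. This shows that, in these two pairs, the size of the step depends on the core it is made on, but it rests on two pairs at a single tested concentration and does not show why the cores differ or what the change would do on any further core.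

The compounds shown leave open how other amines on the thiocarbonyl carbon, such as morpholine or an open-chain dimethylamine, would behave on either core in this assay. They also leave open whether the larger step would persist on a core carrying an ethyl group in place of the methyl group.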